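A few compounds are considered here, and "the series" means these few. Any claim that something is new, unique, unknown or untested is made for them only; others in the source may bear on it.

Measured so far in an assay on Cerebral cortex for displacement of a labelled ligand from Norepinephrine transporter (Rattus norvegicus); on this read-out lower numbers stand for stronger inhibition and higher numbers for weaker inhibition:
compound 1 `COC(=O)[C@@H]1CN(C)CC[C@@H]1c1ccc(-c2cccs2)cc1`: > 50000 nM
compound 2 `COC(=O)[C@@H]1CN(C)CC[C@@H]1c1ccc(-c2nccs2)cc1`: > 50000 nM; > 20000 nM (2 entries)

Compound 1 stands only at a limit of this assay, with no single number given. The value of compound 2 is likewise a limit in every entry (the several entries of compound 2 in this assay, > 50000 nM; > 20000 nM (2 entries)). Within the data shown here, no step between measured compounds is available here. Compound 3 `COC(=O)[C@@H]1CN(C)CC[C@@H]1c1ccc(/C=C\I)cc1` is not yet measured; it differs from compound 1 by 2-iodoethenyl in place of thiophen-2-yl on an aromatic carbon. With no measured comparison behind it, the expected step is an at least 3.3-fold lower number from compound 1 to compound 3 (0.52 log units; beyond the scatter), towards stronger inhibition. Compound 3 is estimated at 15000 nM, within a range from 2000 nM to 60000 nM.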

Compound 3, inhibition constant: > 30000 nM
Compound 3: no number, only a limit; the forecaster's own chance of this, stated with the estimate: 50%; middle value at least 2.0-fold (0.30 log units) from the limit.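

Compound 1 and compound 3 both stand only at limits, and the step between them cannot be read. The compounds shown leave open whether any of them reaches a single measurable number in this assay.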